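The compounds below may be only part of what the source reports. "The series", "measured", "known", "first", "only" and "open" are said of these compounds alone.

Two ureas were tested in an ADME assay on the whole organism with Oryza sativa as the target, tested at 10 uM; on this read-out lower numbers stand for a stronger effect and higher numbers for a weaker effect at the one concentration tested. Compound 1 `CCc1ccccc1NC(=O)N[C@@H](C)c1ccccc1` gives 95%. Compound 2 `C[C@@H](NC(=O)Nc1ccccc1C(C)(C)C)c1ccccc1` gives 17%, the lower of the two numbers and the stronger effect, lying beyond the scatter from compound 1. Compound 3 `C[C@H](NC(=O)Nc1ccccc1C(C)(C)C)c1ccccc1` has not yet been measured in this assay. Its change from compound 2 is the two compounds have the same atoms and bonds and differ only in configuration as drawn: 1 of 1 stereo elements differ; a stereocentre at a saturated chain carbon is drawn R in compound 2 and S in compound 3. Among the compounds with values here, no step between measured compounds shows what such a change does here, so a step of moderate size in the weaker direction is expected, though none beyond the scatter would not surprise. The expected step is a number 38 percentage points higher from compound 2 to compound 3 (beyond the scatter). Compound 3 is estimated at 55%, between 15% and 95%.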

Compound 3, a percentage reported as activity, at one concentration (the size of the read-out at that concentration, not a potency): 100%
Beside the measured number, compound 3's estimate is 45 percentage points below it, outside the stated range (above it).
By their numbers in this assay, from the lowest: compound 2; then compounds 1 and 3 (each within the scatter of the next).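

In this assay, the stereocentre at the saturated chain carbon matters a great deal: drawing it S instead of R gives a number 83 percentage points higher from compound 2 to compound 3 (beyond the scatter). That gap can be assigned to the stereocentre alone, for one reason: the fact that compounds 2 and 3 differ only in the configuration as drawn. With the centre drawn S in both compounds, tert-butyl in place of ethyl on an aromatic carbon gives a number 5 percentage points higher from compound 1 to compound 3 (within the scatter), so this swap alone shows no change beyond the scatter.

Still open, on these data alone, is how ethyl on that aromatic carbon behaves with the centre drawn R. Also open is whether an isopropyl or methoxy group there would match tert-butyl.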